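The source may hold more compounds than are shown below. What is called first, only, known or untested is meant among the compounds shown, and "the series" means these compounds.

Compound 2 `Cc1ccc(-c2nn(-c3ccccc3)cc2C2CC(c3ccc(F)cc3)=NN2c2ccccc2)cc1` gives 110% in a functional assay on the whole organism (Tail) with Rattus norvegicus as the target, in the tail flick test, with a stated time of 60 min, at a dose of 25 mg/kg by the oral route (on this read-out lower numbers stand for less inhibition and higher numbers for more inhibition at the one dose given (going by the name of the read-out)), the higher of the two numbers measured; compound 1 `Fc1ccc(C2=NN(c3ccccc3)C(c3cn(-c4ccccc4)nc3-c3ccc(F)cc3)C2)cc1` gives 41%. Within the data shown here, the single measured step, a number 69 percentage points higher from compound 1 to compound 2 (beyond the scatter), concerns a different exchange and does not bear on the change that leads to compound 3 `COc1ccc(-c2nn(-c3ccccc3)cc2C2CC(c3ccc(F)cc3)=NN2c2ccccc2)cc1`, which is methoxy in place of methyl on an aromatic carbon. Among the measured compounds shown here, no measured step shows what methoxy in place of methyl does, so the expectation rests on compound 2 alone, with room for a drop and little room for a rise. Compound 3 is expected to give 85%, between 45% and 115%, a step of a number 25 percentage points lower from compound 2 to compound 3 (beyond the scatter).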

Compound 3, a percentage reported as inhibition, in the whole organism at one dose (the size of the read-out at that dose, not a potency): 66%
Compound 3: middle estimate off by 19 percentage points, on the high side, and the stated range covers the measured number.
By their numbers in this assay, from the lowest: compound 1; then compound 3; then compound 2.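

In this assay, the size of the effect depends on the group at this position: methoxy in place of methyl gives a number 44 percentage points lower from compound 2 to compound 3 (beyond the scatter) on the 4-methoxyphenyl compound. Methoxy in place of fluoro gives a number 25 percentage points higher from compound 1 to compound 3 (beyond the scatter) at the same place, so the three groups give three separate levels, with methoxy in the middle. Nothing at hand explains this order.

From the compounds shown here alone, whether an amine, a hydroxyl or a longer chain such as ethoxy at this position would fall within this range remains open. So does whether the same order would hold at other doses.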